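This account rests on a few compounds, and the source may have more. Where it says the series, first, only, none or still open, it means among the compounds named here.

Compound 1 `CS(=O)(=O)Nc1ccc(C/N=C(\S)NCc2ccc(Cl)cc2)cc1F` gives 340 nM in an assay for inhibition of transient receptor potential cation channel subfamily V member 1 (Rattus norvegicus), with a stated time of 10 min; on this read-out lower numbers stand for stronger inhibition and higher numbers for weaker inhibition. Compound 2 `CS(=O)(=O)Nc1ccc(C/N=C(\S)NCc2ccc(Br)cc2)cc1F` gives 570 nM, and compound 3 `CS(=O)(=O)Nc1ccc(C/N=C(\S)NCc2ccc(I)cc2)cc1F` gives 630 nM. The steps among the three are a 1.7-fold higher number from compound 1 to compound 2 (0.22 log units; within the scatter), a 1.9-fold higher number from compound 1 to compound 3 (0.27 log units; within the scatter) and a 1.1-fold higher number from compound 2 to compound 3 (0.04 log units; within the scatter); each is within the scatter, so compound 3, though it carries the highest of the three numbers, cannot be separated from compound 1 or compound 2 on these data.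

Compound 4 `CS(=O)(=O)Nc1ccc(C/N=C(\S)NCc2ccc(-c3ccccc3)cc2)cc1F` differs from compound 3 by phenyl in place of iodo on an aromatic carbon. The three measured steps all exchange one halogen for another at this aromatic carbon and bear on the step to compound 4 only in showing that this position has so far tolerated changes of that kind without a shift beyond the scatter; none of them exchanges a halogen for a ring. The expectation is therefore anchored on compound 3 with a wide range rather than derived from a precedent. For compound 4 a number near that of compound 3 is expected, an estimated step of a 1.1-fold lower number from compound 3 to compound 4 (0.02 log units; within the scatter). The estimate for compound 4 is 600 nM, with a range from 150 nM to 2500 nM.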

Compound 4, half-maximal inhibitory concentration: > 30000 nM
Compound 4 ended at the assay's limit; the forecaster's own chance of this, stated with the estimate: 5%; middle value at least 50-fold (1.69 log units) away from the limit.
By their numbers in this assay, from the lowest: compounds 1, 2 and 3 (each within the scatter of the next). At a limit, above all of these: compound 4.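

In this assay compound 4 gives > 30000 nM, which is a limit of the assay and not a number: the limit of > 30000 nM in this assay, at which 1 of the 4 values shown sits.

Phenyl in place of a halogen on this aromatic carbon separates clearly from all three halogen compounds, with an at least 47-fold higher number from compound 3 to compound 4 (1.67 log units; beyond the scatter), an at least 52-fold higher number from compound 2 to compound 4 (1.72 log units; beyond the scatter) and an at least 88-fold higher number from compound 1 to compound 4 (1.94 log units; beyond the scatter), each beyond the scatter. Exchanges among chloro, bromo and iodo had stayed within the scatter, so the position does not accept every change, and replacing a single halogen atom with a six-membered aromatic ring of carbon only is a change it does not accept.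

How far compound 4 lies past the limit cannot be read. Also open, on these data alone, is how a methyl, a tert-butyl, a cyclohexyl ring or a methoxy group on this carbon would read, and so where between iodo and phenyl the tolerance ends.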